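Alkyl variation on the cyanoguanidine series: a methallyl analogue

The compounds below may be only part of what the source reports. "The series", "measured", "known", "first", "only" and "open" are said of these compounds alone.

Measured so far:
compound 1 `CC(C)/N=C(\NC#N)Nc1cccnc1` — 2.5 mg/kg
compound 2 `CC(C)CC(C)(C)/N=C(\NC#N)Nc1cccnc1` — 2.5 mg/kg
compound 3 `CC(C)(C)CC(C)(C)/N=C(\NC#N)Nc1cccnc1` — 50 mg/kg

All three were run in a functional assay on the whole organism (blood, strain Wistar-Okamoto) with Rattus norvegicus as the target, with a stated time of 5 days; on this read-out lower numbers stand for an effect already at smaller amounts and higher numbers for an effect only at larger amounts of compound. Compound 1 stands level with compound 2 at the digits shown, the two together giving the lowest numbers of the three; its furthest neighbour is compound 3, which gives a markedly higher number: a 20-fold higher number from compound 1 to compound 3 (1.30 log units; beyond the scatter). The other steps read no change at the digits printed from compound 1 to compound 2 (within the scatter) and a 20-fold higher number from compound 2 to compound 3 (1.30 log units; beyond the scatter), so the position carrying the isopropyl tolerates one enlargement without change and then turns sharply with a further methyl.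

Compound 4 `C=C(C)C/N=C(\NC#N)Nc1cccnc1` has not yet been measured. It differs from compound 1 by 2-methylprop-2-en-1-yl in place of isopropyl on a double-bonded nitrogen. The change is not an enlargement of the kind seen in the measured steps; the entering group carries one more carbon and a double bond outside aromatic rings. Because no change at the digits printed from compound 1 to compound 2 (within the scatter) showed no change for a modest alteration at this position, while only the bulkiest variant gave a 20-fold higher number from compound 1 to compound 3 (1.30 log units; beyond the scatter), the step to compound 4 is expected to stay within the scatter or rise only slightly: a 1.2-fold higher number from compound 1 to compound 4 (0.08 log units; within the scatter). In this assay compound 4 is therefore expected near 3 mg/kg, between 1.2 mg/kg and 10 mg/kg.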

Compound 4, minimum effective dose: 20 mg/kg
Compound 4: middle estimate off by 6.7-fold (0.82 log units), on the low side; measured number above the stated range.
By their numbers in this assay, from the lowest: compounds 1 and 2 (each within the scatter of the next); then compound 4; then compound 3.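

The exchange of isopropyl for 2-methylprop-2-en-1-yl gives an 8.0-fold higher number from compound 1 to compound 4 (0.90 log units; beyond the scatter) in this assay and so shows that this place on the double-bonded nitrogen responds to a small exchange, 4 heavy atoms for 3, and not only to the largest group of the set. Compound 2 at 2.5 mg/kg and compound 4 at 20 mg/kg show that a larger group here need not give the higher number, so the numbers do not follow group size alone, with compound 2 as the case against such a trend. No measurement is at hand that explains this step.

On these data alone, whether the double bond or the arrangement of the carbons carries the step stays open. A saturated 2-methylpropyl group at the same place would separate the two.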